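Removing the amino group from an active aminothiophene-type anilide

The compounds below may be only part of what the source reports. "The series", "measured", "known", "first", "only" and "open" are said of these compounds alone.

Of the compounds shown here, two have been tested in a functional assay on HUVEC cells (Homo sapiens), read by fluorescence and microscopy, with a stated time of 6 h, tested at 10 uM; a lower number here means a stronger effect, a higher number a weaker effect of the compound at the concentration tested. Compound 1 `COc1cc2sc(Nc3ccccc3)c(C#N)c2cc1OC` gives 77% in this assay. Compound 2 `N#Cc1c(Nc2ccc(N)cc2)sc2ccccc12` gives 1% in this assay, the lowest of the two numbers and far beyond the scatter from compound 1. Compound 3 `N#Cc1c(Nc2ccccc2)sc2ccccc12` has not yet been measured. It differs from compound 2 in one place: hydrogen in place of amino on an aromatic carbon. Compound 3 therefore carries the same unsubstituted anilino group as compound 1, but on the core of compound 2, without the two methoxy groups. Since compound 2 gives 1% while compound 1 gives 77%, the expectation is a step upward, beyond the scatter, toward a weaker effect. Compound 3 is estimated to give 40% in this assay, within a range of 5% to 85%, a change of a number 39 percentage points higher from compound 2 to compound 3 (beyond the scatter) that is expected but uncertain.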

Compound 3, a percentage reported as activity, at one concentration (the size of the read-out at that concentration, not a potency): 81%
The estimate for compound 3 lay 41 percentage points below the measured number; low and high end bracket the measured number.
By their numbers in this assay, from the lowest: compound 2; then compounds 1 and 3 (each within the scatter of the next).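

Hydrogen in place of amino on an aromatic carbon, para to a large group, gives a number 80 percentage points higher from compound 2 to compound 3 (beyond the scatter) in this assay. Compounds 1 and 2 differ in more than one place, so they could not tie their gap to any single change, whereas this pair shows that the low number of compound 2 depends on the amino group at this position. Nothing measured here bears on why the step is so large.

From the compounds shown here alone, it remains open whether another group at this position, such as hydroxyl, methylamino or acetamido, would keep the number low or whether only the amino group does so. Going by these compounds, it is also open whether adding an amino group to compound 1, with its two methoxy groups, would bring a similar step.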